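The source may report more compounds than this note shows. Statements on the series, on what has been measured and on what is new or still open speak of the compounds shown alone.

Measured so far in a functional assay on PC-3 cells (Homo sapiens) for antiproliferative activity, read by MTT assay, with a stated time of 48 h; on this read-out lower numbers stand for stronger inhibition and higher numbers for weaker inhibition:
Compound 1 `COc1cc(CN(C(=O)CSc2nc3ccccc3s2)c2cc(OC)c(OC)c(OC)c2)cc(OC)c1OC`: > 80000 nM, which is a limit.
Compound 2 `COc1ccc(CN(C(=O)CSc2nc3ccccc3s2)c2cc(OC)c(OC)c(OC)c2)cc1Br`: 16000 nM.

For the measured compounds named here, compound 2 holds the only actual number, since compound 1 reached a limit. Compound 3 `COc1cc(N(Cc2ccc(F)cc2)C(=O)CSc2nc3ccccc3s2)cc(OC)c1OC` has 4-fluorophenyl in place of 3-bromo-4-methoxyphenyl on a saturated chain carbon bound to an amide-type nitrogen. Going by the values given here, the only measured step at this place is an at least 5.0-fold lower number from compound 1 to compound 2 (0.69 log units; beyond the scatter). It is beyond the scatter, but it involves neither group's replacement by 4-fluorophenyl and so sets no firm direction. No step beyond the scatter is therefore expected in this assay, with a slight lean towards a higher number. The expected change is a 1.6-fold higher number from compound 2 to compound 3 (0.19 log units; within the scatter). Compound 3 is estimated at 25000 nM, with an expected range of 8000 nM to 70000 nM.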

Compound 3, half-maximal inhibitory concentration: 50800 nM
The estimate for compound 3 lay 2.0-fold (0.31 log units) below the measured number; measured number inside the range.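

On a saturated chain carbon bound to an amide-type nitrogen, this assay now gives a step between two measured numbers: 4-fluorophenyl in place of 3-bromo-4-methoxyphenyl gives a 3.2-fold higher number from compound 2 to compound 3 (0.50 log units; beyond the scatter). Against 3,4,5-trimethoxyphenyl, 4-fluorophenyl gives an at least 1.5-fold lower number from compound 1 to compound 3 (0.19 log units; that floor lies within the scatter), which sets no firm order. Compound 1 stands at a limit, and this step can give only a floor: the limit of > 80000 nM in this assay, at which 1 of the 3 values shown sits.

The bromine and the methoxy leave together, so the compounds shown do not separate their shares in the step. As far as these compounds go, how a carboxylic acid or an amine on that ring would read remains open.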